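Swapping one aryl group on two related cores

The source may hold more compounds than are shown below. What is called first, only, known or untested is meant among the compounds shown, and "the series" means these compounds.

Compound 1 `CC#CC(CC(=O)O)c1ccc(OCc2ccc3nc(-c4ccc(C(F)(F)F)cc4)cn3c2)cc1` and compound 2 `CC#CC(CC(=O)O)c1ccc(OCc2ccc3nc(-c4ccccc4C)cn3c2)cc1` share one core and differ only in the aryl group attached to it. In an assay on isolated protein for agonist activity at Free fatty acid receptor 1 (Homo sapiens) (a lower number here means that less compound is needed, a higher number that more compound is needed for the effect), compound 2 gives 389 nM, and compound 1 gives 558 nM. The change between them, (4-(trifluoromethyl)phenyl in place of 2-methylphenyl on an aromatic carbon), made a step of a 1.4-fold higher number from compound 2 to compound 1 (0.16 log units; within the scatter). Compound 3 `CC#CC(CC(=O)O)c1ccc(OCc2ccn3cc(-c4ccccc4C)nc3c2)cc1` carries the same 2-methylphenyl group as compound 2 but is built from the same atoms joined differently; the difference between the two cores is not broken down here. In this assay compound 3 gives 459 nM, close to both earlier numbers. Compound 4 `CC#CC(CC(=O)O)c1ccc(OCc2ccn3cc(-c4ccc(C(F)(F)F)cc4)nc3c2)cc1` is compound 3 with the swap already seen once: 4-(trifluoromethyl)phenyl in place of 2-methylphenyl on an aromatic carbon. This is the same change as in the measured pair, at a matching place on the core. Because the measured step was a 1.4-fold higher number from compound 2 to compound 1 (0.16 log units; within the scatter), the step expected for compound 4 is a 1.4-fold higher number from compound 3 to compound 4 (0.15 log units; within the scatter), a shift that may not stand out from ordinary repeat-to-repeat variation. Compound 4 is therefore estimated at 650 nM in this assay, with a likely range from 300 nM to 1400 nM.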

Compound 4, half-maximal effective concentration: 674 nM
Estimate against measurement, compound 4: 1.0-fold (0.02 log units) below; low and high end bracket the measured number.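

Carried over to the core of compound 3, 4-(trifluoromethyl)phenyl in place of 2-methylphenyl gives a 1.5-fold higher number from compound 3 to compound 4 (0.17 log units; within the scatter) in this assay. The step on this core agrees with the one on the first core: the same change on two cores in this assay, a 1.4-fold higher number (0.16 log units; within the scatter) from compound 2 to compound 1 and a 1.5-fold higher number (0.17 log units; within the scatter) from compound 3 to compound 4, 1.0-fold (0.01 log units) apart, within the scatter of two such steps. This shows that, on these two cores, the swap leaves the number about where it was, but it does not show that the swap has a real effect, since each step on its own stays within the scatter, and two cores cannot establish a rule for the whole series or show that a larger step would carry over in the same way.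

The compounds shown test only these two aryl groups, so it remains open whether another group on the phenyl ring, such as an amine or a nitrile, would give matching steps on the two cores. They also leave open whether the two cores would still track each other in a different assay.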